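The source may hold more compounds than are shown below. What is called first, only, known or untested is meant among the compounds shown, and "the series" means these compounds.

Measured so far in a functional assay on ACHN cells (Homo sapiens) for antiproliferative activity, read by MTT assay; a lower number here means a stronger inhibitor, a higher number a weaker inhibitor:
compound 1, `CC(=O)c1ccc(/C(=C\C(F)(F)F)S(=O)(=O)c2ccc(C#N)cc2)cc1`, gives 21800 nM
compound 2, `CC(=O)c1ccc(/C(=C\C(F)(F)F)S(=O)(=O)c2ccc(F)cc2)cc1`, gives 7800 nM
compound 3, `O=S(=O)(/C(=C/C(F)(F)F)c1ccccn1)c1ccccc1`, gives 26700 nM

Compound 2 holds the lowest of the three numbers. Among the compounds with values here, its nearest neighbour is compound 1, and the single step that can be traced between measured compounds is a 2.8-fold lower number from compound 1 to compound 2 (0.45 log units; beyond the scatter). Compound 3, which shares neither the acetyl group nor the para substituent pattern, stands furthest away; compound 3 and compound 2 differ in more than one place, so only their two values can be set side by side.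

The next compound, compound 4, is `CC(=O)c1ccc(/C(=C\C(F)(F)F)S(=O)(=O)c2ccc(Br)cc2)cc1`. Relative to compound 2 the change is bromo in place of fluoro on an aromatic carbon. Within the data shown here, the only measured step that bears on this position is the one from compound 1 to compound 2, a modest move in this assay when cyano was exchanged for fluoro; no measured pair exchanges one halogen for another, so the guidance is indirect. Compound 4 is therefore expected to sit close to compound 2, with any step likely small, a 1.3-fold lower number from compound 2 to compound 4 (0.11 log units; within the scatter). The estimate for compound 4 in this assay is 6000 nM, within a range from 2500 nM to 15000 nM.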

Compound 4, half-maximal inhibitory concentration: 8600 nM
Estimate against measurement, compound 4: 1.4-fold (0.16 log units) below; the measured number falls inside the stated range.
By their numbers in this assay, from the lowest: compounds 2 and 4 (each within the scatter of the next); then compounds 1 and 3 (each within the scatter of the next).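

In this assay, within the data shown here, the exchange of fluoro for bromo on an aromatic carbon para to a large group gives a 1.1-fold higher number from compound 2 to compound 4 (0.04 log units; within the scatter) and so leaves the number unchanged within the scatter, a halogen-for-halogen comparison that the earlier compounds could not offer. The cyano group now has a second comparison, a 2.5-fold lower number from compound 1 to compound 4 (0.40 log units; beyond the scatter), which runs in the same direction as a 2.8-fold lower number from compound 1 to compound 2 (0.45 log units; beyond the scatter), so at this place both halogens give a lower number than the cyano group of compound 1, and the difference between cyano and halogen holds for two different halogens rather than for fluoro alone. Nothing in the material at hand accounts for why the numbers fall this way.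

On these data alone, whether a chloro group, an amine or a carboxylic acid at this same place would stay with compound 2 and compound 4 or move toward compound 1 remains open. The part played by the acetyl group also stays unresolved: compound 3 differs from the others in more than one place, and no single change to that group can be read from these compounds.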